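Capping the Phenol: Methyl on Oxygen in a Chalcone Series

A few compounds are considered here, and "the series" means these few. Any claim that something is new, unique, unknown or untested is made for them only; others in the source may bear on it.

Compound 1, `COc1ccc(-c2cc3ccccc3nc2/C=C/C(=O)c2ccc(F)cc2)cc1`, gives 5450 nM in a functional assay on MCF7 cells (Homo sapiens) for antiproliferative activity, read by XTT assay, with a stated time of 72 h; a higher number here means a weaker inhibitor, a lower number a stronger inhibitor.
Compound 2, `COc1ccc(-c2cc3ccccc3nc2/C=C/C(=O)c2ccc(O)cc2)cc1`, gives 6710 nM in this assay.

Among the measured compounds shown here, only two compounds have been measured, and they sit close together. Compound 2 carries the hydroxy group where compound 1 carries fluoro, and the step between them, a 1.2-fold higher number from compound 1 to compound 2 (0.09 log units; within the scatter), lies within the scatter, so neither compound can be called stronger or weaker than the other on these numbers.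

Compound 3, `COc1ccc(C(=O)/C=C/c2nc3ccccc3cc2-c2ccc(OC)cc2)cc1`, differs from compound 2 by methyl in place of hydrogen on an oxygen on an aromatic ring; in other words, hydroxy becomes methoxy on the phenyl that carries the carbonyl. For the measured compounds named here, no measured step changes this oxygen itself. Going by the values given here, the only step that bears on the same position is the one from compound 1 to compound 2, and it stayed within the scatter when fluoro gave way to hydroxy. On that slender basis, the expected step is a 1.1-fold lower number from compound 2 to compound 3 (0.05 log units; within the scatter), with no change beyond the scatter. Compound 3 is therefore estimated at 6000 nM, within a range of 2500 nM to 15000 nM.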

Compound 3, half-maximal inhibitory concentration: 7380 nM
The estimate for compound 3 lay 1.2-fold (0.09 log units) below the measured number; low and high end bracket the measured number.
By their numbers in this assay, from the lowest: compounds 1, 2 and 3 (each within the scatter of the next).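

In this assay, putting methyl on this oxygen gives a 1.1-fold higher number from compound 2 to compound 3 (0.04 log units; within the scatter), so capping the phenol brings no change that can be told from the scatter, and the hydrogen on this oxygen shows no measurable part in these numbers. The new compound also completes a set of three groups at this place, with a 1.4-fold higher number from compound 1 to compound 3 (0.13 log units; within the scatter), which leaves fluoro, hydroxy and methoxy all within the scatter of one another. Nothing measured here speaks to the reason for this flat result.

Going by these compounds, whether this place stays as tolerant for an amine, a carboxylic acid or a longer chain on the oxygen remains open. The other methoxy group is the same in all three compounds, so these numbers say nothing about its contribution.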